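This account rests on a few compounds, and the source may have more. Where it says the series, first, only, none or still open, it means among the compounds named here.

In a functional assay on HEK293 cells for agonist activity at D(4) dopamine receptor (Homo sapiens), read by FLIPR (on this read-out lower numbers stand for an effect already at smaller amounts and higher numbers for an effect only at larger amounts of compound), three compounds with a shared core have been measured. Compound 1 `O=C(NCN1CCC(c2cccc[n+]2[O-])CC1)c1cnccc1Cl` gives 1290 nM, compound 2 `O=C(CN1CCC(c2cccc[n+]2[O-])CC1)NC1CCCCC1` gives 294 nM, and compound 3 `C=Cc1cccc(C(=O)NCN2CCC(c3cccc[n+]3[O-])CC2)c1` gives 68 nM. Compound 2 thus stands second highest of the three numbers, nearest to compound 3 and furthest from compound 1. Going by the values given here, the only step between compounds differing in one place is a 19-fold lower number from compound 1 to compound 3 (1.28 log units; beyond the scatter), and it concerns the group on the carbonyl carbon, not the amide-type nitrogen. Compound 4 `Cc1cccc(C)c1NC(=O)CN1CCC(c2cccc[n+]2[O-])CC1` differs from compound 2 by 2,6-dimethylphenyl in place of cyclohexyl on an amide-type nitrogen. Among the compounds with values here, no measured step covers this change, so its direction is open; a modest step of a 1.5-fold lower number from compound 2 to compound 4 (0.17 log units; within the scatter) is expected. Compound 4 is therefore estimated in this assay at 200 nM, between 50 nM and 800 nM.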

Compound 4, half-maximal effective concentration: 346 nM
For compound 4 the middle estimate is 1.7-fold (0.24 log units) below the measured one; low and high end bracket the measured number.
By their numbers in this assay, from the lowest: compound 3; then compounds 2 and 4 (each within the scatter of the next); then compound 1.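

In this assay the exchange on the amide-type nitrogen gives a 1.2-fold higher number from compound 2 to compound 4 (0.07 log units; within the scatter) and so, at this position, 2,6-dimethylphenyl and cyclohexyl cannot be told apart. For this one pair, a six-membered aromatic ring of carbon only and a six-membered non-aromatic ring of carbon only give values within the scatter of each other. No evidence is at hand to explain this result.

Open remains how an amine, a carboxylic acid or a longer chain on this nitrogen would read. Also open, as far as these compounds go, is whether plain phenyl, without the two methyl groups, would match these two groups.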